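A few compounds are considered here, and "the series" means these few. Any claim that something is new, unique, unknown or untested is made for them only; others in the source may bear on it.

Measured so far in an ADME assay on a cell-free system (plasma, Homo sapiens) for metabolic stability; on this read-out lower numbers stand for a shorter-lived compound and higher numbers for a longer-lived compound:
compound 1 `Cc1ncc([N+](=O)[O-])n1CCOC(=O)CCCC(=O)OCCn1c([N+](=O)[O-])cnc1C` gives 0.61 h
compound 2 `CS(=O)(=O)N(COC(=O)c1ccccc1)c1ccc([N+](=O)[O-])cc1Oc1ccccc1` gives 0.0322 h
compound 3 `C[C@H](NC(=O)[C@H](N)CC(=O)OCc1ccccc1)C(=O)O` gives 3.52 h

Compound 2 stands lowest of the three numbers; compound 1 lies well above it, beyond the scatter, and compound 3 furthest above. Going by the values given here, no pair of measured compounds differing in a single place is at hand, so the move to compound 4 `CC(C)(C)C(=O)OCN(c1ccc([N+](=O)[O-])cc1Oc1ccccc1)S(C)(=O)=O` rests on the structural change alone: tert-butyl in place of phenyl on a carbonyl carbon. The change sits on a carbonyl carbon whose other neighbours are oxygen next to a carbonyl group; beyond it the compound is unchanged. Among the compounds with values here, with no step of this kind measured, the expected step is small, upward if anything, and within the scatter. For compound 4 a half-life of 0.05 h is estimated, in the range 0.02 h to 0.13 h. That is an expected step of a 1.6-fold higher number from compound 2 to compound 4 (0.19 log units; within the scatter).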

Compound 4, half-life: 1.7 h
The estimate for compound 4 lay 34-fold (1.53 log units) below the measured number, and the stated range ends below it.
By their numbers in this assay, from the lowest: compound 2; then compound 1; then compound 4; then compound 3.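

In this assay, going by these compounds alone, the group on this carbonyl carbon proves a strong lever: tert-butyl in place of phenyl gives a 53-fold higher number from compound 2 to compound 4 (1.72 log units; beyond the scatter) as the first single-place step. With the rest of the compound unchanged, this one exchange carries the whole difference in half-life. Nothing at hand accounts for the size of this step.

As far as these compounds go, whether the step belongs to tert-butyl itself or to the departure of phenyl stays open. Methyl, isopropyl or cyclohexyl on the same carbonyl carbon would separate the two readings.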